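The source may hold more compounds than are shown below. What is called first, only, known or untested is meant among the compounds shown, and "the series" means these compounds.

Going by the values given here, in a functional assay on BV-2 cells (Mus musculus) for inhibition, read by ELISA, with a stated time of 16 h (a lower number here means a stronger inhibitor, a higher number a weaker inhibitor), compound 3 `Cc1cc(-c2cccc(F)c2)nnc1N1CCN(c2ncccn2)CC1` gives 33500 nM, the only actual number among the three measured compounds. Compound 1 `Cc1cc(C)c(N2CCN(c3ncccn3)CC2)nn1` returns only the limit of the assay, > 100000 nM. Compound 2 `Cc1cc(C(C)C)nnc1N1CCN(c2ncccn2)CC1` likewise returns only the limit, > 100000 nM. Among the compounds with values here, compound 3 therefore stands as the single compound with a readable result, while the other two sit at the limit of > 100000 nM in this assay, at which 2 of the 3 values shown sit, so their order relative to each other cannot be read. The shared core carries a 3-fluorophenyl group in compound 3 where the others carry a methyl or an isopropyl group, and the two steps that bear on this are an at least 2.9-fold lower number from compound 1 to compound 3 (0.47 log units; beyond the scatter) and an at least 2.9-fold lower number from compound 2 to compound 3 (0.47 log units; beyond the scatter). The remaining step, a step that the two limits leave unreadable from compound 1 to compound 2, is unreadable because both values are limits.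

Compound 4 `Cc1cc(-c2ccsc2)nnc1N1CCN(c2ncccn2)CC1` keeps everything of compound 3 except this one group: thiophen-3-yl in place of 3-fluorophenyl on an aromatic carbon. Within the data shown here, both groups are flat aromatic rings, and the measured steps show only that such a ring gives a lower number than a small alkyl group; they say nothing about one ring against another. For compound 4 the expected step is a 1.2-fold higher number from compound 3 to compound 4 (0.08 log units; within the scatter), within the usual scatter. For compound 4 the estimate is 40000 nM, between 15000 nM and 100000 nM.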

Compound 4, half-maximal inhibitory concentration: 2400 nM
Compound 4: the middle estimate sits 17-fold (1.22 log units) above what was measured; measured number below the stated range.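

Until now, this position had only separated an aromatic ring from a small alkyl group, and the swap of one ring for another shows that the choice of ring matters as well: a 14-fold lower number from compound 3 to compound 4 (1.14 log units; beyond the scatter). In this assay the thiophen-3-yl group also stands well apart from both alkyl groups, with an at least 41-fold lower number from compound 2 to compound 4 (1.61 log units; beyond the scatter) and an at least 41-fold lower number from compound 1 to compound 4 (1.61 log units; beyond the scatter). These two steps are only minimum sizes, since each starts from a limit rather than a number: the limit of > 100000 nM in this assay, at which 2 of the 4 values shown sit.

This single swap changes the ring from six-membered to five-membered, removes the fluorine and brings in a sulfur atom all at once, so the compounds shown cannot tell which of these differences goes with the large step. Also open, going by these compounds, is how other groups would read at this position, such as a plain phenyl ring, which would separate the fluorine from the ring itself, a furan-3-yl ring, which would keep the five-membered ring with oxygen in place of sulfur, or an amine such as morpholine.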